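The source may hold more compounds than are shown below. What is called first, only, known or untested is meant among the compounds shown, and "the series" means these compounds.

Of the compounds shown here, three have been measured in a functional assay on HEK293 cells for agonist activity at D(4) dopamine receptor (Homo sapiens), read by FLIPR; on this read-out higher numbers stand for an effect only at larger amounts of compound and lower numbers for an effect already at smaller amounts. Compound 1 `Cc1cccc(C(=O)NCN2CCC(c3ccccn3)CC2)c1` gives 9 nM, compound 2 `Cc1cc(C)cc(NC(=O)CN2CCC(c3cccc[n+]3[O-])CC2)c1` gives 52 nM, and compound 3 `C=Cc1cccc(C(=O)NCN2CCC(c3cccc[n+]3[O-])CC2)c1` gives 68 nM. Compound 2 thus holds the second highest of the three numbers: its value and that of compound 3 lie within the usual scatter of each other, while compound 1 shows a clearly lower number. Compound 4 `O=C(CN1CCC(c2cccc[n+]2[O-])CC1)Nc1ccc(F)cc1F` has not yet been measured; it differs from compound 2 in one place: 2,4-difluorophenyl in place of 3,5-dimethylphenyl on an amide-type nitrogen. For the measured compounds named here, no step between measured compounds that differ in one place is available, and the size of this change is not known from the data. The step of a 1.5-fold higher number from compound 2 to compound 4 (0.19 log units; within the scatter) is expected to be no larger than the scatter. For compound 4 in this assay the estimate is 80 nM, within a range of 25 nM to 250 nM.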

Compound 4, half-maximal effective concentration: 103 nM
The estimate for compound 4 lay 1.3-fold (0.11 log units) below the measured number; the range from low to high includes it.
By their numbers in this assay, from the lowest: compound 1; then compounds 2, 3 and 4 (each within the scatter of the next).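

In this assay, for the compounds shown here, 2,4-difluorophenyl in place of 3,5-dimethylphenyl on an amide-type nitrogen gives a 2.0-fold higher number from compound 2 to compound 4 (0.30 log units; within the scatter) and is the first step that can be read at this position. The two groups have the same number of heavy atoms, and this read-out does not tell them apart. Nothing measured here speaks to the reason for this result. As far as these compounds go, whether a group without a phenyl ring, such as an amine or a carboxylic acid, would read differently at this position stays open. So does the effect of a single fluorine or a single methyl on the ring.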